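A few compounds are considered here, and "the series" means these few. Any claim that something is new, unique, unknown or untested is made for them only; others in the source may bear on it.

Measured so far:
- compound 1, `CN1CCN(c2ccc(Nc3ncc4nc(Nc5ccc(F)cc5)n([C@@H]5CCN(C(=O)OC(C)(C)C)C5)c4n3)cc2)CC1`: 27 nM
- compound 2, `CN1CCN(c2ccc(Nc3ncc4nc(Nc5ccc(F)cc5)n([C@@H]5CCN(S(=O)(=O)C6CC6)C5)c4n3)cc2)CC1`: 2.5 nM
- compound 3, `CN1CCN(c2ccc(Nc3ncc4nc(Nc5ccc(F)cc5)n([C@H]5CCCNC5)c4n3)cc2)CC1`: 38 nM

All three share one core and differ only in the group carried on an aromatic nitrogen of that core. In a functional assay on HCC827 cells (Homo sapiens) for antiproliferative activity, read by MTT assay, with a stated time of 72 h (a higher number here means a weaker inhibitor, a lower number a stronger inhibitor), compound 3 gives the highest of the three numbers. Its nearest neighbour is compound 1, and the gap between them, a 1.4-fold higher number from compound 1 to compound 3 (0.15 log units; within the scatter), lies within the usual scatter. Its furthest neighbour is compound 2, from which it is separated by a 15-fold higher number from compound 2 to compound 3 (1.18 log units; beyond the scatter), a step well beyond the scatter. The third step, an 11-fold lower number from compound 1 to compound 2 (1.03 log units; beyond the scatter), shows that changing what sits on the ring nitrogen of the saturated ring can move the number a great deal.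

Compound 4, `CN1CCN(c2ccc(Nc3ncc4nc(Nc5ccc(F)cc5)n(-c5cccc(NC(=O)CO)c5)c4n3)cc2)CC1`, has not yet been measured. It differs from compound 3 in one place: 3-(((hydroxymethyl)carbonyl)amino)phenyl in place of piperidin-3-yl on an aromatic nitrogen. The measured steps that bear on this are the two that alter the same aromatic nitrogen, one small and one large, so this position tolerates change in either direction. Among the compounds with values here, no measured compound carries an aromatic ring or an amide at this position, so the direction rests on weak footing. A modest step is expected, a 1.9-fold lower number from compound 3 to compound 4 (0.28 log units; within the scatter), with compound 4 estimated at 20 nM in this assay, within a range from 5 nM to 80 nM.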

Compound 4, half-maximal inhibitory concentration: 7.5 nM
Beside the measured number, compound 4's estimate is 2.7-fold (0.43 log units) above it; measured number inside the range.
By their numbers in this assay, from the lowest: compound 2; then compound 4; then compounds 1 and 3 (each within the scatter of the next).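

Until now, every group on this aromatic nitrogen was a non-aromatic ring, and compound 4 shows that an aromatic ring of carbon only, as 3-(((hydroxymethyl)carbonyl)amino)phenyl, can stand here in this assay and still lower the number, with a 5.1-fold lower number from compound 3 to compound 4 (0.70 log units; beyond the scatter) and with a 3.6-fold lower number from compound 1 to compound 4 (0.56 log units; beyond the scatter) as the two steps. It does not match the cyclopropylsulfonyl compound, however, as there is a 3.0-fold higher number from compound 2 to compound 4 (0.48 log units; beyond the scatter) and compound 2 keeps the lowest number of the four. No measurement shown here offers an explanation for these steps.

The aromatic ring and its amide chain enter together, so the compounds shown cannot separate what each contributes, and a plain phenyl group, or the same ring carrying an amine or a carboxylic acid instead of the amide chain, would help to divide the step between them. From the compounds shown here alone, it also stays open whether a cyclopropylsulfonyl group, carried on the nitrogen attached to this phenyl ring, would bring the number of compound 4 closer to that of compound 2.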